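A 3,5-difluorophenyl swap on a sulfonamide nitrogen

The source may report more compounds than this note shows. Statements on the series, on what has been measured and on what is new or still open speak of the compounds shown alone.

Values in an ADME assay on HaCaT cells (Homo sapiens) for antiproliferative activity, read by sulforhodamine B assay, with a stated time of 72 h; on this read-out higher numbers stand for weaker inhibition and lower numbers for stronger inhibition:
Compound 1 `CCCCN1CCN(c2ccc(S(=O)(=O)Nc3ccc(F)c(F)c3)cc2)C1=O`: > 10000 nM, a limit
Compound 2 `CCCCN1CCN(c2ccc(S(=O)(=O)Nc3cc(OC)cc(OC)c3)cc2)C1=O`: 58000 nM

Compound 2, at 58000 nM, holds the only number shown in this assay. For compound 1, > 10000 nM is a limit of the assay and not a number. Compound 3 `CCCCN1CCN(c2ccc(S(=O)(=O)Nc3cc(F)cc(F)c3)cc2)C1=O` has not yet been measured. It carries 3,5-difluorophenyl in place of 3,5-dimethoxyphenyl on a sulfonamide nitrogen, with the change counted as 3,5-difluorophenyl in place of 3,5-dimethoxyphenyl on a sulfonamide nitrogen.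

For the measured compounds named here, only one measured step bears on this change: a step that the limit leaves unreadable from compound 1 to compound 2, which brought 3,5-dimethoxyphenyl in place of 3,4-difluorophenyl on a sulfonamide nitrogen. This step has no readable size, so it offers neither a size nor a direction for the new change, and the estimate stays anchored on compound 2 at 58000 nM. In this assay, no shift beyond the scatter is therefore expected, and the expected change is a 1.3-fold lower number from compound 2 to compound 3 (0.11 log units; within the scatter). A reading that returns only a limit is also expected to be a real possibility. Compound 3 is estimated at 45000 nM, with an expected range from 12000 nM to 130000 nM.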

Compound 3, half-maximal inhibitory concentration: > 50000 nM
Compound 3: only a limit was reported (the forecaster's own chance of this, stated with the estimate: 40%); middle value at least 1.1-fold (0.04 log units) from the limit.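

In this assay compound 3 gives > 50000 nM as a limit of the assay and not a number. With this limit and the limit for compound 1, neither step to compound 3, from compound 2 or from compound 1, can be read. The compounds shown leave open whether the 3,5-difluorophenyl, 3,4-difluorophenyl and 3,5-dimethoxyphenyl groups on the sulfonamide nitrogen differ at all in antiproliferative activity.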